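The source may hold more compounds than are shown below. What is called first, only, known or untested is meant among the compounds shown, and "the series" means these compounds.

Of the compounds shown here, two have so far been measured in a functional assay on HT-29 cells (Homo sapiens) for cytotoxicity, read by MTT assay, with a stated time of 24 h, tested at 0.64 ug/mL; on this read-out higher numbers stand for a stronger effect at the one concentration tested and lower numbers for a weaker effect. Compound 1 `Cn1cnnc1SCC(=O)Nc1ccc(-c2nc(-c3ccccc3)c(-c3ccccc3)n2C)cc1` gives 32%, while compound 2 `CN(C)/C=C/N1CCN(CC(=O)Nc2ccc(-c3nc(-c4ccccc4)c(-c4ccccc4)n3C)cc2)CC1` gives 3.1%. Within the data shown here, the one measured step, a number 28.9 percentage points lower from compound 1 to compound 2 (beyond the scatter), is the only comparison available, and it leaves compound 2 as the lower of the two numbers. Compound 3 `Cn1c(-c2ccc(NC(=O)CN3CCN(Cc4ccc(Cl)cc4)CC3)cc2)nc(-c2ccccc2)c1-c1ccccc1` is not yet measured. It differs from compound 2 in one place: 4-chlorobenzyl in place of 2-(dimethylamino)ethenyl on an amine nitrogen in a ring. Among the measured compounds shown here, no measured step alters the group on this ring nitrogen, so the only guide is that the step from compound 1 to compound 2 shows that the group on the saturated chain carbon bound to the carbonyl carbon can move the read-out by a modest amount. A change of similar size is expected here, most likely upward from the low value of compound 2, though its direction is not secured. For compound 3 the expected step is a number 11.9 percentage points higher from compound 2 to compound 3 (beyond the scatter), giving an estimate of 15%, within a range from 0% to 40%.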

Compound 3, a percentage reported as activity, at one concentration (the size of the read-out at that concentration, not a potency): 11.3%
For compound 3 the middle estimate is 3.7 percentage points above the measured one; the range from low to high includes it.
By their numbers in this assay, from the lowest: compounds 2 and 3 (each within the scatter of the next); then compound 1.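

In this assay, this is the only step shown that alters the group on the ring nitrogen, and it is a number 8.2 percentage points higher from compound 2 to compound 3 (within the scatter). Replacing 2-(dimethylamino)ethenyl with 4-chlorobenzyl brings in a six-membered aromatic ring of carbon and a chlorine, and removes a nitrogen and a hydrogen-bond acceptor, yet the read-out does not separate the two groups beyond the usual scatter of repeated measurements. No measured property of these groups is available to explain this result.

The compounds shown leave open whether a much smaller group on this ring nitrogen, such as methyl, or a longer chain ending in a carboxylic acid would give a similar read-out. They also leave open whether the two groups would still read alike with a different group in place of the chlorine, such as a methoxy group.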